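This account rests on a few compounds, and the source may have more. Where it says the series, first, only, none or still open, it means among the compounds named here.

Measured in a functional assay on MCF7 cells (Homo sapiens) for antiproliferative activity, read by MTT assay, with a stated time of 24 h; a higher number here means a weaker inhibitor, a lower number a stronger inhibitor:
- compound 1 `c1ccc(C2=NN(c3ccc(-c4ccccc4)nn3)C(c3ccccc3)C2)cc1`: 23800 nM
- compound 2 `Clc1ccc(C2=NN(c3ccc(-c4ccccc4)nn3)C(c3ccccc3)C2)cc1`: 10000 nM
- compound 3 `COc1ccc(C2CC(c3ccc(Cl)cc3)=NN2c2ccc(-c3ccccc3)nn2)c(OC)c1`: the value here is a limit of the assay, > 100000 nM

Compound 2 gives the lowest of the two numbers that are numbers; the nearest is compound 1, with the step of a 2.4-fold lower number from compound 1 to compound 2 (0.38 log units; beyond the scatter) after chloro in place of hydrogen on an aromatic carbon. The step of an at least 10-fold higher number from compound 2 to compound 3 (1.00 log units; beyond the scatter) runs into the limit (the limit of > 100000 nM in this assay, at which 1 of the 3 values shown sits), after 2,4-dimethoxyphenyl in place of phenyl on a saturated ring carbon.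

Compound 4 `COc1ccc(C2=NN(c3ccc(-c4ccccc4)nn3)C(c3ccccc3)C2)cc1` differs from compound 2 by methoxy in place of chloro on an aromatic carbon. Going by the values given here, no measured step swaps chloro for methoxy on this ring; the step from compound 1 to compound 2 shows what removing the chloro costs, and the step from compound 2 to compound 3 shows methoxy groups on the other aryl ring being unfavourable. A move back toward the level of compound 1, or somewhat beyond it, is therefore expected, of about a 2.2-fold higher number from compound 2 to compound 4 (0.34 log units; beyond the scatter) in this assay. Compound 4 is expected to give 22000 nM in this assay, with a range of 7000 nM to 70000 nM.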

Compound 4, half-maximal inhibitory concentration: > 100000 nM
Compound 4 gave a limit, no number (the forecaster's own chance of this, stated with the estimate: 12%); at least 4.5-fold (0.65 log units) between middle value and limit.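

Placed para to a large group on the six-membered aromatic ring, a single methoxy is enough to lose the activity seen with chloro in this assay, giving an at least 10-fold higher number from compound 2 to compound 4 (1.00 log units; beyond the scatter). Going by these compounds alone, it also falls short of hydrogen at the same place, with an at least 4.2-fold higher number from compound 1 to compound 4 (0.62 log units; beyond the scatter), so hydrogen, chloro and methoxy do not simply sit close together here: chloro improves on hydrogen with a 2.4-fold lower number from compound 1 to compound 2 (0.38 log units; beyond the scatter), whereas methoxy moves the other way, a change of direction that the earlier compounds could not show at this position. Compound 4 gives > 100000 nM, which is a limit of the assay and not a number, so both new steps are bounds and their full size remains unknown: the limit of > 100000 nM in this assay, at which 2 of the 4 values shown sit.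

The compounds shown leave open whether the loss is specific to methoxy or extends to other groups at this place, such as fluoro, methyl, hydroxy or an amine. They also give no cause for the opposite directions of chloro and methoxy, and no reading of whether the same order holds in any other assay.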